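A few compounds are considered here, and "the series" means these few. Any claim that something is new, unique, unknown or untested is made for them only; others in the source may bear on it.

Compounds measured so far:
compound 1, `C=CCN(C)C(=O)c1ccc(C(CC)(CC)c2ccc(OCC(=O)C(C)(C)C)c(C)c2)n1CC`: 21600 nM
compound 2, `CCn1c(C(=O)NCCN)ccc1C(CC)(CC)c1ccc(OCC(O)C(C)(C)C)c(C)c1`: 10 nM
compound 3, `C=CCN(C)C(=O)c1ccc(C(CC)(CC)c2ccc(OCC(O)C(C)(C)C)c(C)c2)n1CC`: 3950 nM

In an assay on HL-60 cells for agonist activity at vitamin D3 receptor (Homo sapiens), read by microscopy, with a stated time of 96 h (on this read-out higher numbers stand for an effect only at larger amounts of compound and lower numbers for an effect already at smaller amounts), compound 1 stands at the highest of the three numbers. Its nearest neighbour is compound 3, reached by a 5.5-fold lower number from compound 1 to compound 3 (0.74 log units; beyond the scatter), a modest change at the chain bound to the aromatic oxygen. Among the compounds with values here, compound 2 lies far beneath both; its difference from compound 1 is large, though no single-place step joins the two.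

Compound 4, `CCOc1ccc(NC(=O)c2ccc(C(CC)(CC)c3ccc(OCC(=O)C(C)(C)C)c(C)c3)n2CC)cc1`, differs from compound 1 at the amide: (4-ethoxyphenyl)amino in place of allyl(methyl)amino on a carbonyl carbon. The step that bears on this place is a 400-fold higher number from compound 2 to compound 3 (2.60 log units; beyond the scatter), a large step showing that what sits on this carbonyl carbon moves the number a great deal. Within the data shown here, the entering group, like the one in compound 2, brings one hydrogen-bond donor, but it also brings an aromatic ring for which no measured step exists, so the direction is not settled by the data. A moderate drop is expected, a 3.1-fold lower number from compound 1 to compound 4 (0.49 log units; beyond the scatter), with a wide range. For compound 4 the estimate in this assay is 7000 nM, between 1000 nM and 40000 nM.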

Compound 4, half-maximal effective concentration: > 50000 nM
Compound 4: a limit, no number (the forecaster's own chance of this, stated with the estimate: 10%); at least 7.1-fold (0.85 log units) between middle value and limit.
By their numbers in this assay, from the lowest: compound 2; then compound 3; then compound 1. At a limit, above all of these: compound 4.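

In this assay compound 4 gives > 50000 nM, which is a limit and not a number: the limit of > 50000 nM in this assay, at which 1 of the 4 values shown sits. The change of allyl(methyl)amino to (4-ethoxyphenyl)amino on the carbonyl carbon gives an at least 2.3-fold higher number from compound 1 to compound 4 (0.36 log units; beyond the scatter), so the one hydrogen-bond donor that enters with this group does not come with a lower number here. The earlier step at this place, a 400-fold higher number from compound 2 to compound 3 (2.60 log units; beyond the scatter), joined two compounds carrying the 1-hydroxy-2,2-dimethylpropyl chain, whereas this one shows that the same carbonyl carbon also moves the number when the (tert-butyl)carbonyl chain is present, and that the move can be upward from a number that was already the highest of those measured.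

From the compounds shown here alone, how far the true value of compound 4 lies past its limit stays open, as does whether 1-hydroxy-2,2-dimethylpropyl in place of (tert-butyl)carbonyl would bring it down as in a 5.5-fold lower number from compound 1 to compound 3 (0.74 log units; beyond the scatter). Also open, going by these compounds, is what a primary amine or a carboxylic acid on a longer chain would do on this carbonyl carbon, and whether (2-aminoethyl)amino keeps its low number alongside the (tert-butyl)carbonyl chain.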